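The compounds below may be only part of what the source reports. "The series", "measured", "known", "first", "only" and "open" are said of these compounds alone.

Measured compounds:
compound 1, `Cc1ccc(CSc2cc(Cl)c(C)cc2S(=O)(=O)/N=C(\N)n2nc(C)cc2-c2ccccc2)cc1`, with 89000 nM in a functional assay on MCF7 cells (Homo sapiens) for cytotoxicity, read by MTT assay, with a stated time of 72 h; on this read-out lower numbers stand for stronger inhibition and higher numbers for weaker inhibition
compound 2, `Cc1cc(S(=O)(=O)/N=C(\N)n2nccc2-c2ccccc2)c(SCc2ccc(C(F)(F)F)cc2)cc1Cl`, with 25000 nM in this assay

Of the two compounds measured in this assay, compound 1 gives the highest number, and the nearest neighbour, compound 2, lies beyond the usual scatter below it. Among the compounds with values here, compound 1 and compound 2 differ at more than one position, so their two values show only that compound 2 inhibits the cells more strongly than compound 1; nothing further can be drawn from that pair.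

Compound 3, `Cc1cc(-c2ccccc2)n(/C(N)=N/S(=O)(=O)c2cc(C)c(Cl)cc2SCc2cccc(Cl)c2)n1`, has not yet been measured in this assay. It departs from compound 1 in a single place: 3-chlorophenyl in place of 4-methylphenyl on a saturated chain carbon bound to a sulfur. The change exchanges one 7-atom aromatic group for another of the same size, with no donor or acceptor added or removed, on the saturated chain carbon bound to a sulfur that links this group to the shared core.

Within the data shown here, with no measured pair that isolates this exchange, the step is expected to be small, running from compound 1 to compound 3 as a 1.5-fold lower number from compound 1 to compound 3 (0.17 log units; within the scatter), and it may well stay inside the scatter. Compound 3 is therefore estimated at 60000 nM in this assay, with a likely range from 20000 nM to 150000 nM.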

Compound 3, half-maximal inhibitory concentration: 25000 nM
Estimate against measurement, compound 3: 2.4-fold (0.38 log units) above; low and high end bracket the measured number.
By their numbers in this assay, from the lowest: compounds 2 and 3 (each within the scatter of the next); then compound 1.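

In this assay, replacing 4-methylphenyl with 3-chlorophenyl on a saturated chain carbon bound to a sulfur gives a 3.6-fold lower number from compound 1 to compound 3 (0.55 log units; beyond the scatter) and so shows that the number responds to a change at this position, which the earlier pair, differing at more than one position, could not show. The shift is a modest one, and it appears although the heavy-atom count, the six-membered aromatic ring of carbon only and the absence of hydrogen-bond donors and acceptors in the group all stay the same, so these counts alone do not set the value here. Nothing measured here speaks to why the number moved.

The exchange alters both the substituent and its place on the ring at once, so the compounds shown cannot separate the contribution of the chlorine from that of its location; 3-methylphenyl and 4-chlorophenyl on the same carbon would pull the two apart. From the compounds shown here alone, it also remains open how unsubstituted phenyl would compare at this position, and whether the same exchange would give a step of similar size on the core of compound 2.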